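The source may report more compounds than this note shows. Statements on the series, on what has been measured and on what is new or still open speak of the compounds shown alone.

The series shares the core of compound 1 `CCN(CC)c1ccc2cc(C(=O)c3ccc(N4CCN(C(=O)CN5CCNCC5)CC4)cc3)oc2c1`, which in a functional assay on SGC-7901 cells (Homo sapiens) for cytotoxicity, read by MTT assay, with a stated time of 48 h (a higher number here means a weaker inhibitor, a lower number a stronger inhibitor), gives 1220 nM. Compound 2 `CCN(CC)c1ccc2cc(C(=O)c3ccc(N4CCN(C(=O)CN5CCN(C(=O)/C=C/c6ccccc6)CC5)CC4)cc3)oc2c1` carries a (2-phenylethenyl)carbonyl on an amine nitrogen in a ring and in this assay gives 1140 nM; compound 3 `CCN(CC)c1ccc2cc(C(=O)c3ccc(N4CCN(C(=O)CN5CCN(Cc6ccc(F)c(F)c6)CC5)CC4)cc3)oc2c1` carries a 3,4-difluorobenzyl on that nitrogen and gives 1780 nM. As a bare number compound 3 reads highest of the three, but every step to it lies within the scatter: its nearest neighbour is compound 1 with a 1.5-fold higher number from compound 1 to compound 3 (0.16 log units; within the scatter), its furthest compound 2 with a 1.6-fold higher number from compound 2 to compound 3 (0.19 log units; within the scatter), and a 1.1-fold lower number from compound 1 to compound 2 (0.03 log units; within the scatter) is equally flat, so the three compounds cannot be ranked against one another.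

Compound 4 `CCN(CC)c1ccc2cc(C(=O)c3ccc(N4CCN(C(=O)CN5CCN(Cc6ccc(C#N)cc6)CC5)CC4)cc3)oc2c1` differs from compound 3 by 4-cyanophenyl in place of 3,4-difluorophenyl on a saturated chain carbon bound to an amine nitrogen in a ring. Among the measured compounds shown here, none of the measured steps alters a substituent on this aryl ring; the steps that touch the benzyl position, a 1.5-fold higher number from compound 1 to compound 3 (0.16 log units; within the scatter) and a 1.6-fold higher number from compound 2 to compound 3 (0.19 log units; within the scatter), both stay within the scatter, and so does a 1.1-fold lower number from compound 1 to compound 2 (0.03 log units; within the scatter). On that basis no step beyond the scatter is expected from compound 3 to compound 4 in this assay, a 1.2-fold lower number from compound 3 to compound 4 (0.07 log units; within the scatter). Compound 4 is therefore estimated at 1500 nM, with an expected range from 700 nM to 3200 nM.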

Compound 4, half-maximal inhibitory concentration: 26300 nM
Estimate against measurement, compound 4: 18-fold (1.24 log units) below, outside the stated range (above it).
By their numbers in this assay, from the lowest: compounds 2, 1 and 3 (each within the scatter of the next); then compound 4.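

In this assay, among the compounds shown here, the aryl group on a saturated chain carbon bound to an amine nitrogen in a ring is not a silent place: 4-cyanophenyl in place of 3,4-difluorophenyl gives a 15-fold higher number from compound 3 to compound 4 (1.17 log units; beyond the scatter) and is the first change to leave the scatter. The shift holds against both other groups on that nitrogen, with a 22-fold higher number from compound 1 to compound 4 (1.33 log units; beyond the scatter) measured against the free amine and a 23-fold higher number from compound 2 to compound 4 (1.36 log units; beyond the scatter) against the (2-phenylethenyl)carbonyl, so 4-cyanobenzyl stands apart from three compounds that cannot be ranked against one another, and a benzyl group as such does not set the outcome, since compound 3 carries one too. Nothing at hand accounts for this step.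

The two benzyl groups differ both in the nitrile and in the two fluorines, so these compounds leave open whether the shift follows the gain of the one or the loss of the other, which an unsubstituted benzyl would begin to separate. A carboxylic acid or an amide in place of the nitrile would test whether the shift is tied to the nitrile itself.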